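Branching the Thioether Chain on a Cytotoxic Core

The source may report more compounds than this note shows. Statements on the series, on what has been measured and on what is new or still open speak of the compounds shown alone.

Compound 1 `CCCCCNc1nc(SCC)nc2ncccc12` is one of two measured compounds. In a functional assay on MDA-MB-231 cells (Homo sapiens) for cytotoxicity, read by neutral red uptake, with a stated time of 72 h (a higher number here means a weaker inhibitor, a lower number a stronger inhibitor), compound 1 gives 1300 nM. Compound 2 `CCCCCCNc1nc(SCC)nc2ncccc12` carries a methyl in place of hydrogen on a saturated chain carbon, five bonds along the chain from a nitrogen on an aromatic ring, and in this assay compound 2 gives 1400 nM; the step of a 1.1-fold higher number from compound 1 to compound 2 (0.03 log units; within the scatter) lies within the scatter. Compound 1 thus holds the lowest of the two numbers shown, with compound 2 too close for any order to be claimed.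

Compound 3 `CCCCCNc1nc(SC(C)C)nc2ncccc12` has not yet been measured. It differs from compound 1 by methyl in place of hydrogen on a saturated chain carbon bound to a saturated chain carbon and a sulfur. Within the data shown here, no measured step touches this part of the molecule; the only step available, a 1.1-fold higher number from compound 1 to compound 2 (0.03 log units; within the scatter), adds a single carbon elsewhere and barely moved the number. On that slender basis the step of a 1.1-fold higher number from compound 1 to compound 3 (0.03 log units; within the scatter) is expected to stay within the scatter. Compound 3 is estimated at 1400 nM, with a range from 700 nM to 2800 nM.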

Compound 3, half-maximal inhibitory concentration: 5600 nM
Beside the measured number, compound 3's estimate is 4.0-fold (0.60 log units) below it; measured number outside the range, above it.
By their numbers in this assay, from the lowest: compounds 1 and 2 (each within the scatter of the next); then compound 3.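

In this assay, one added methyl on a saturated chain carbon bound to a saturated chain carbon and a sulfur, turning ethylsulfanyl into isopropylsulfanyl, gives a 4.3-fold higher number from compound 1 to compound 3 (0.63 log units; beyond the scatter), so this small change at this position yields a weaker inhibitor. Among these compounds, the only earlier step, a 1.1-fold higher number from compound 1 to compound 2 (0.03 log units; within the scatter), also added a methyl in place of hydrogen, but five bonds along the chain from a nitrogen on an aromatic ring, which shows that the same change does not give the same result at these two places. No evidence at hand accounts for this difference.

The compounds shown leave open whether a straight propyl chain on the sulfur would match the isopropyl result, and how a methyl or a tert-butyl group would fare there. From the compounds shown here alone, it also remains open whether the same step would appear with the longer chain of compound 2.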